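The source may hold more compounds than are shown below. What is called first, only, known or untested is meant among the compounds shown, and "the series" means these compounds.

Measured compounds and their results:

Compound 1 `CNCc1cn(S(=O)(=O)c2ccoc2)c(-c2cccnc2F)c1F`: 95%
Compound 2 `CNCc1cn(S(=O)(=O)c2cc(OC)ccn2)c(-c2cccnc2F)c1F`: 95%
Compound 3 `CNCc1cn(S(=O)(=O)c2ccc(OC)cn2)c(-c2cccnc2F)c1F`: 95%

All three were tested in a functional assay on the whole organism (strain Jcl:Sprague-Dawley) for inhibition, with Rattus norvegicus as the target, with stated times of 3 min and 3 h, at a dose of 1 mg/kg by the intravenous route; a lower number here means less inhibition, a higher number more inhibition at the dose given (going by the name of the read-out). Compound 3 stands level with compounds 1 and 2: the step of no change at the digits printed from compound 1 to compound 3 (within the scatter) and the step of no change at the digits printed from compound 2 to compound 3 (within the scatter) are both within the scatter, as is the step of no change at the digits printed from compound 1 to compound 2 (within the scatter). Each of these steps swaps one aromatic group on the sulfonyl sulfur for another, and none of them moved the read-out.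

Compound 4 `CNCc1cn(S(=O)(=O)c2cccc(C)n2)c(-c2cccnc2F)c1F` has not yet been measured. The change from compound 3 is 6-methylpyridin-2-yl in place of 5-methoxypyridin-2-yl on a sulfonyl sulfur. Within the data shown here, no measured step swaps a methoxy group for a methyl group, so the closest guidance is that three different exchanges at the same sulfonyl sulfur all left the inhibition unchanged in this assay. The step of a number 3 percentage points lower from compound 3 to compound 4 (within the scatter) is therefore expected to lie within the scatter, with no direction beyond it. Compound 4 is estimated to give 92%, within a range from 78% to 99%.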

Compound 4, a percentage reported as inhibition, in the whole organism at one dose (the size of the read-out at that dose, not a potency): 91%
The estimate for compound 4 lay 1 percentage points above the measured number; the measured number falls inside the stated range.
By their numbers in this assay, from the lowest: compounds 4, 1, 2 and 3 (each within the scatter of the next).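

In this assay, among these compounds, the group 6-methylpyridin-2-yl is the first on the sulfonyl sulfur in this set to hold no oxygen atom, yet the read-out stays within the scatter of all three earlier compounds (a number 4 percentage points lower from compound 3 to compound 4 (within the scatter) and a number 4 percentage points lower from compound 2 to compound 4 (within the scatter) and a number 4 percentage points lower from compound 1 to compound 4 (within the scatter)). A methoxy group on the pyridine ring is therefore not needed for this level of inhibition among these compounds, and a methyl group serves as well. All four compounds were read at a single dose, so this shows the size of the effect at that dose and not a difference in potency.

From the compounds shown here alone, whether an open propyl chain or a pyridine ring bearing an amine or a carboxylic acid on the sulfonyl sulfur would hold the inhibition stays open, as does how these compounds would separate at a smaller dose. Nothing available explains why these exchanges leave the read-out in place.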